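A methyl on nitrogen: from compound 3 to compound 4

This account rests on a few compounds, and the source may have more. Where it says the series, first, only, none or still open, it means among the compounds named here.

In an assay on cells for inhibition of Voltage-dependent T-type calcium channel subunit alpha-1H (Homo sapiens), read by FLIPR and calcium flux, with stated times of 600 s and 300 s (a higher number here means a weaker inhibitor, a lower number a stronger inhibitor), compound 3 `NCCCOc1ccc(CNc2nc3ccc(Oc4ccc(C(F)(F)F)cc4)cc3s2)cc1` gives 112000 nM, the lowest of the three numbers measured; compound 1 `CN(Cc1ccc(OCCCN)cc1)c1nc2ccc(Oc3ccc(O)cc3)cc2s1` gives 165000 nM and compound 2 `CN(Cc1ccc(OCCCN)cc1)c1nc2ccc(Oc3cccc(C(F)(F)F)c3)cc2s1` gives 239000 nM. Within the data shown here, the one measured step, a 1.4-fold higher number from compound 1 to compound 2 (0.16 log units; within the scatter), concerns an exchange on the oxygen-linked aromatic ring and not the nitrogen. Compound 4 `CN(Cc1ccc(OCCCN)cc1)c1nc2ccc(Oc3ccc(C(F)(F)F)cc3)cc2s1` differs from compound 3 by methyl in place of hydrogen on a nitrogen on an aromatic ring. Among the measured compounds shown here, compound 1 and compound 2 already carry this methyl, yet no pair in the set isolates that change alone, so no measured step bears directly on it. The account therefore expects no step beyond the scatter, estimating a 1.3-fold higher number from compound 3 to compound 4 (0.13 log units; within the scatter). For compound 4 the estimate in this assay is 150000 nM, with a range from 60000 nM to 400000 nM.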

Compound 4, half-maximal inhibitory concentration: 248000 nM
Compound 4: middle estimate off by 1.7-fold (0.22 log units), on the low side, within the range that was stated.
By their numbers in this assay, from the lowest: compounds 3, 1, 2 and 4 (each within the scatter of the next, the first and the last beyond it).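

In this assay, among these compounds, the methyl on the nitrogen brings a 2.2-fold higher number from compound 3 to compound 4 (0.35 log units; beyond the scatter) as the only new step beyond the scatter, so this position, untested by the earlier compounds, does register the change. With the methyl present, the aromatic exchanges give a 1.0-fold higher number from compound 2 to compound 4 (0.02 log units; within the scatter) and a 1.5-fold higher number from compound 1 to compound 4 (0.18 log units; within the scatter) and stay within the scatter. No measured evidence accounts for the step. Going by these compounds, whether an ethyl or an acetyl on this nitrogen would go further remains open, as does whether the methyl step holds with 4-hydroxyphenyl or 3-(trifluoromethyl)phenyl on the oxygen.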